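This account rests on a few compounds, and the source may have more. Where it says the series, first, only, none or still open, it means among the compounds named here.

Working notes on the series, protein binding.

Compound 1 `Cc1ccc([C@@H](C)Oc2cc3onc(CCC(=O)O)c3cc2Cl)nc1`, compound 2 `CCc1cc2oc(=O)n(CCC(=O)O)c2cc1Cl` and compound 3 `COCCOc1cc2oc(=O)n(CCC(=O)O)c2cc1Cl` have been run in an ADME assay on a cell-free system (plasma, Homo sapiens) for protein binding. Compound 1 gives 99.7%, compound 2 gives 98.7% and compound 3 gives 70.7%. Among these three, compound 1 holds the lowest unbound fraction; the step from compound 1 to compound 2 and from compound 1 to compound 3 are both beyond the scatter. Among the compounds with values here, the only single-point step measured so far is a 23-fold higher unbound fraction from compound 2 to compound 3 (1.35 log units; beyond the scatter), which concerns a different position and a different group.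

Compound 4 `C[C@@H](Oc1cc2onc(CCC(=O)O)c2cc1Cl)c1ccccn1` is to be measured in this assay. It differs from compound 1 by hydrogen in place of methyl on an aromatic carbon. Within the data shown here, no measured step covers the loss of a methyl on the shared core, so nothing in the data sets the size of this step. Loss of one carbon is a small change; the expectation is a step of a 1.7-fold higher unbound fraction from compound 1 to compound 4 (0.22 log units; within the scatter), that is a somewhat higher unbound fraction but close to the scatter. Compound 4 is therefore expected at 99.5%, within 99% to 99.8%.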

Compound 4, plasma protein binding: 97.8%
Estimate against measurement, compound 4: 4.4-fold (0.64 log units) (unbound fraction) below; measured number outside the range, below it.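

Within the data shown here, the change from 5-methylpyridin-2-yl to pyridin-2-yl is the first measured step at this position in this assay and amounts to a 7.3-fold higher unbound fraction from compound 1 to compound 4 (0.87 log units; beyond the scatter) on the shared core. The earlier compounds shown here said nothing about this carbon; this pair shows that one methyl, on an aromatic carbon two atoms from the ring nitrogen and para to a large group, is enough to move the unbound fraction beyond the scatter. Nothing available bears on what lies behind a step of this size.

The compounds shown carry only methyl or hydrogen on this carbon, so the course of the step with a fluorine, a methoxy group or a longer chain such as ethyl stays open. Going by these compounds, whether loss of a methyl gives a similar step on other carbons of the same ring also stays open.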